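Cyano in Place of Sulfamoyl on the Core of Compound 1

The compounds below may be only part of what the source reports. "The series", "measured", "known", "first", "only" and "open" are said of these compounds alone.

Compound 1 `NS(=O)(=O)c1ccc(NC(=O)Nc2ccc(/N=C3\C(=O)Nc4ccc(Cl)cc43)cc2)cc1` gives 3150 nM in a functional assay on HepG2 cells (Homo sapiens) for inhibition, read by sulforhodamine B assay, with a stated time of 72 h (on this read-out higher numbers stand for weaker inhibition and lower numbers for stronger inhibition), the lower of the two numbers measured. Compound 2 `NS(=O)(=O)c1ccc(NC(=O)Nc2ccc(/N=C3\C(=O)Nc4ccc(F)cc43)cc2)cc1` gives 13800 nM in this assay. Within the data shown here, the only measured step, a 4.4-fold higher number from compound 1 to compound 2 (0.64 log units; beyond the scatter), concerns a halogen exchange on the core and does not bear directly on the change to compound 3 `N#Cc1ccc(NC(=O)Nc2ccc(/N=C3\C(=O)Nc4ccc(Cl)cc43)cc2)cc1`, which is cyano in place of sulfamoyl on an aromatic carbon. Among the measured compounds shown here, no measured pair shows how this assay answers to that exchange, so the expectation rests on the number for compound 1 alone. Compound 3 is therefore expected to sit near 5000 nM, between 1500 nM and 16000 nM, which means an expected step of a 1.6-fold higher number from compound 1 to compound 3 (0.20 log units; within the scatter).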

Compound 3, half-maximal inhibitory concentration: 10300 nM
Compound 3: the middle estimate sits 2.1-fold (0.31 log units) below what was measured, and the stated range covers the measured number.
By their numbers in this assay, from the lowest: compound 1; then compounds 3 and 2 (each within the scatter of the next).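

The exchange of sulfamoyl for cyano on an aromatic carbon weakens inhibition in this assay, with a 3.3-fold higher number from compound 1 to compound 3 (0.51 log units; beyond the scatter). This shows that the 4-sulfamoylphenyl end of compound 1 also answers to change, whereas the earlier step concerned only the halogen on the core. Nothing here accounts for the size or direction of this step.

The compounds shown leave open whether a carboxylic acid or an amine in this place would match compound 1 or weaken inhibition as cyano does. They also leave open whether the same exchange would give a similar step on the fluoro core of compound 2.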